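The source may report more compounds than this note shows. Statements on the series, on what has been measured and on what is new or still open speak of the compounds shown alone.

Compound 2 `CC#CC(CC(=O)O)c1ccc(OCc2ccc(C(=O)N3CCN(c4ccc(C(C)(C)C)cc4)CC3)s2)cc1` carries a 4-(tert-butyl)phenyl on the amine nitrogen of the ring, and in a functional assay on HEK293 cells for agonist activity at Free fatty acid receptor 1 (Homo sapiens), read by fluorescence and calcium flux (on this read-out lower numbers stand for an effect already at smaller amounts and higher numbers for an effect only at larger amounts of compound), compound 2 gives 417 nM. Among the measured compounds shown here, that is the lowest of the two numbers measured so far; compound 1 `CC#CC(CC(=O)O)c1ccc(OCc2ccc(C(=O)N3CCN(c4cccnc4)CC3)s2)cc1`, which bears pyridin-3-yl at the same position, gives 1140 nM in this assay, and the single measured step, a 2.7-fold lower number from compound 1 to compound 2 (0.44 log units; beyond the scatter), lies beyond the scatter.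

Compound 3 `CC#CC(CC(=O)O)c1ccc(OCc2ccc(C(=O)N3CCN(c4ccc(Cl)cc4)CC3)s2)cc1` is the next member of the series. The change from compound 2 is chloro in place of tert-butyl on an aromatic carbon. For the measured compounds named here, no measured step replaces tert-butyl by chloro directly; the only measured step concerns a different exchange on the same nitrogen, so it bears on compound 3 only loosely. Since both compounds carrying a six-membered carbon ring there have not been compared with a chloro substituent, a step in either direction is possible, and a small rise in the number is expected, with the step of a 1.6-fold higher number from compound 2 to compound 3 (0.19 log units; within the scatter) likely within or just beyond the scatter. Compound 3 is therefore expected to give about 650 nM in this assay, estimated to fall between 250 nM and 1700 nM.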

Compound 3, half-maximal effective concentration: 133 nM
Beside the measured number, compound 3's estimate is 4.9-fold (0.69 log units) above it, and the stated range ends above it.
By their numbers in this assay, from the lowest: compound 3; then compound 2; then compound 1.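

In this assay, the group on this aromatic carbon moves the number on its own: chloro in place of tert-butyl gives a 3.1-fold lower number from compound 2 to compound 3 (0.50 log units; beyond the scatter). A group of 4 heavy atoms is thus not needed at this position for the lower number, since 1 heavy atom serves better here, and no ring, hydrogen-bond donor, hydrogen-bond acceptor or net charge enters or leaves in the exchange; taken as a whole, 4-chlorophenyl in place of pyridin-3-yl on the ring nitrogen gives an 8.6-fold lower number from compound 1 to compound 3 (0.93 log units; beyond the scatter), the widest step in the set so far. Nothing at hand speaks to what lies behind these steps.

The compounds shown leave open whether fluoro, bromo, methyl or methoxy on the same carbon would continue this trend or reverse it, and whether the number follows the count of heavy atoms at all, as only tert-butyl and chloro can be compared there. They also leave open whether chloro would bring a similar step on the pyridin-3-yl ring of compound 1.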